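The source may hold more compounds than are shown below. What is called first, only, known or untested is meant among the compounds shown, and "the series" means these compounds.

Measured in an ADME assay on microsomes from liver (Homo sapiens) for metabolic stability, read by LC-MS, tested at 1 uM; a lower number here means slower removal, a higher number faster removal of the compound:
- Compound 1 `c1cc([C@H]2CC[C@]3(CC2)OOC2(O3)C3CC4CC(C3)CC2C4)ccc1OCC1CCNCC1`: < 7 mL.min-1.g-1 (a limit)
- Compound 2 `NCCCCOc1ccc([C@H]2CC[C@]3(CC2)OOC2(O3)C3CC4CC(C3)CC2C4)cc1`: < 7 mL.min-1.g-1 (a limit)

In this assay compound 2 stands at < 7 mL.min-1.g-1, a limit of the assay and not a number. That is the limit of < 7 mL.min-1.g-1 in this assay, at which 2 of the 2 values shown sit. Compound 3 `O[C@H]1CC[C@H](NCCCOc2ccc([C@H]3CC[C@]4(CC3)OOC3(O4)C4CC5CC(C4)CC3C5)cc2)CC1` differs from compound 2 by (4-hydroxycyclohexyl)amino in place of aminomethyl on a saturated chain carbon, three bonds along the chain from an oxygen on an aromatic ring. Within the data shown here, the only measured step is a step that the two limits leave unreadable from compound 1 to compound 2, so it offers no size to carry over. With no readable step to go on, the expected at least 1.1-fold higher number from compound 2 to compound 3 (0.05 log units; that floor lies within the scatter) is no larger than the usual scatter, and no direction can be expected. For compound 3 the estimate is 8 mL.min-1.g-1, with an expected range from 5 mL.min-1.g-1 to 20 mL.min-1.g-1.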

Compound 3, intrinsic clearance in microsomes in the liver assay: < 7 mL.min-1.g-1
Compound 3: a limit, no number; the forecaster's own chance of this, stated with the estimate: 55%; middle value at least 1.1-fold (0.05 log units) away from the limit.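

In the liver assay compound 3 gives < 7 mL.min-1.g-1 as a limit of the assay and not a number. Its steps from compound 1 and compound 2 therefore cannot be read. In a physicochemical assay for solubility, read by nephelometry, measured as kinetic solubility, with a stated time of 30 min (a higher number here means a more soluble compound, a lower number a less soluble compound), compound 2 gives 50 ug/mL as a measured number. In the physicochemical assay compound 3 gives > 100 ug/mL as a limit of the assay and not a number. In the physicochemical assay this reads as an at least 2.0-fold higher number from compound 2 to compound 3 (0.30 log units; that floor lies within the scatter) for the change of aminomethyl to (4-hydroxycyclohexyl)amino. The compounds shown leave open whether these three differ at all in removal: the limit of < 7 mL.min-1.g-1 in the liver assay, at which 3 of the 3 values shown sit.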